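The source may hold more compounds than are shown below. What is called first, only, known or untested is meant among the compounds shown, and "the series" means these compounds.

Measured so far in an ADME assay on the whole organism (Rattus norvegicus, strain Sprague-Dawley) for pharmacokinetics, using cassette dosing, at a dose of 1 mg/kg by the oral route; on this read-out lower numbers stand for lower oral bioavailability and higher numbers for higher oral bioavailability:
- Compound 1 `O=C(Nc1ccc2[nH]c(=O)oc2c1)C(=O)N1CCN(c2ccc(F)cc2)CC1`: 39.3%
- Compound 2 `O=C(Nc1ccc2[nH]c(=O)oc2c1)C(=O)N1CCN(c2ccc(F)c(Cl)c2)CC1`: 24.6%

Of these two compounds, compound 2 stands lowest, and the gap is beyond the scatter. Compound 3 `O=C(Nc1ccc2[nH]c(=O)oc2c1)C(=O)N1CCN(c2ccc(Cl)c(F)c2)CC1` has the same atoms as compound 2, joined differently: 4-chloro-3-fluorophenyl in place of 3-chloro-4-fluorophenyl on an amine nitrogen in a ring. Among the compounds with values here, only one measured step bears on this change, the modest a number 14.7 percentage points lower from compound 1 to compound 2 (beyond the scatter), which came with chloro in place of hydrogen on an aromatic carbon. That step adds a chlorine, whereas compound 3 keeps both halogens and only exchanges them, so it offers no direct measure of such a swap. The expectation therefore rests on staying close to compound 2 at 24.6%, with no change beyond the scatter in this assay. The expected change is a number 2.4 percentage points higher from compound 2 to compound 3 (within the scatter). For compound 3 the estimated value is 27%, within an expected range of 14% to 41%.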

Compound 3, oral bioavailability: 28.2%
Compound 3: middle estimate off by 1.2 percentage points, on the low side, and the stated range covers the measured number.
By their numbers in this assay, from the lowest: compounds 2 and 3 (each within the scatter of the next); then compound 1.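

In this assay the exchange of the two halogens gives a number 3.6 percentage points higher from compound 2 to compound 3 (within the scatter), so the 4-chloro-3-fluorophenyl and 3-chloro-4-fluorophenyl groups on the amine nitrogen in a ring cannot be told apart on this read-out. The step from the 4-fluorophenyl group is a number 11.1 percentage points lower from compound 1 to compound 3 (beyond the scatter), which shows that the lower number seen earlier with the 3-chloro-4-fluorophenyl group also comes with the other arrangement of the same two halogens. Nothing at hand gives a cause for either step.

The compounds shown leave open whether a plain phenyl group or a 4-chlorophenyl group would stand with compound 1 or with compound 2. They also leave open how a methoxy or nitrile group in place of the chloro would read.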